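A few compounds are considered here, and "the series" means these few. Any claim that something is new, unique, unknown or untested is made for them only; others in the source may bear on it.

In a functional assay (blood) for inhibition, with Homo sapiens as the target (a lower number here means a stronger inhibitor, a higher number a weaker inhibitor), compound 1 `COC(=O)c1cc(-c2ccccc2)c2ccc(OCc3cccc(C4(O)CCOCC4)c3)cc2c1` gives 100 nM and compound 2 `N#Cc1cc(-c2ccccc2)c2ccc(OCc3cccc(C4(O)CCOCC4)c3)cc2c1` gives 100 nM, so compound 2 stands level with compound 1. Compound 3 `Cn1nnnc1-c1cc(-c2ccccc2)c2ccc(OCc3cccc(C4(O)CCOCC4)c3)cc2c1` differs from compound 2 at one place: 1-methyl-1H-tetrazol-5-yl in place of cyano on an aromatic carbon. Within the data shown here, the only measured guide is a swap at that same place, with cyano in place of methoxycarbonyl on an aromatic carbon. With no change at the digits printed from compound 1 to compound 2 (within the scatter) as that guide, no change beyond the scatter is expected in this assay, in either direction, although the entering group is a different one. The expected step is no change at the digits printed from compound 2 to compound 3 (within the scatter). For compound 3 the estimate is 100 nM, within an expected range of 40 nM to 250 nM.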

Compound 3, half-maximal inhibitory concentration: > 10000 nM
Compound 3 ended at the assay's limit; the forecaster's own chance of this, stated with the estimate: 3%; middle value at least 100-fold (2.00 log units) from the limit.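

In this assay, this position does not accept every group: 1-methyl-1H-tetrazol-5-yl in place of cyano gives an at least 100-fold higher number from compound 2 to compound 3 (2.00 log units; beyond the scatter), and in place of methoxycarbonyl it gives an at least 100-fold higher number from compound 1 to compound 3 (2.00 log units; beyond the scatter). Compound 1 and compound 2 stood level, so only compound 3 shows that a change at this aromatic carbon can matter greatly. The value of compound 3 is a limit, not a number: the limit of > 10000 nM in this assay, at which 1 of the 3 values shown sits.

The compounds shown leave open which feature of the 1-methyl-1H-tetrazol-5-yl group matters. As far as these compounds go, how a primary amide or a carboxylic acid would behave at this place also remains open.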